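Chloro for methyl on the aryl ring of compound 3

The source may report more compounds than this note shows. Statements on the series, on what has been measured and on what is new or still open speak of the compounds shown alone.

Three compounds of this series have numbers in an assay on RBL-1 cells for inhibition of Polyunsaturated fatty acid 5-lipoxygenase (Rattus norvegicus); a higher number here means a weaker inhibitor, a lower number a stronger inhibitor. Compound 1 `Cc1ccccc1N1CCNC(=O)N1` gives 386000 nM. Compound 2 `O=C1NCCN(c2cccc(OCc3ccccc3)c2)N1` gives 1100 nM. Compound 3 `Cc1cccc(N2CC(C)NC(=O)N2)c1` gives 19000 nM. Among these three numbers compound 3 stands second highest: nearest to it is compound 2, whose lower number lies beyond the scatter; furthest is compound 1, whose higher number also lies beyond the scatter. Compound 2 and compound 3 both carry their substituent meta to the group of 8 heavy atoms, and both sit well under compound 1.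

Compound 4 `CC1CN(c2cccc(Cl)c2)NC(=O)N1` differs from compound 3 by chloro in place of methyl on an aromatic carbon. Within the data shown here, no pair of measured compounds shows this exact exchange, so there is no direct precedent for the size of the step in this assay. A small step is expected, at most modestly downward, and possibly none beyond the scatter. Compound 4 is expected to give 12000 nM, within 4000 nM to 40000 nM. The expected step is a 1.6-fold lower number from compound 3 to compound 4 (0.20 log units; within the scatter), estimated to stay close to the scatter.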

Compound 4, half-maximal inhibitory concentration: 2700 nM
Estimate against measurement, compound 4: 4.4-fold (0.65 log units) above, and the stated range ends above it.
By their numbers in this assay, from the lowest: compound 2; then compound 4; then compound 3; then compound 1.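

In this assay, among these compounds, chloro in place of methyl gives a 7.0-fold lower number from compound 3 to compound 4 (0.85 log units; beyond the scatter) and so shows that this aromatic carbon, meta to a group of 8 heavy atoms, responds to a one-atom exchange, which the earlier compounds could not show since no two of them differ in one place. The exchange leaves the heavy-atom count and the donor and acceptor counts unchanged, so those counts alone do not separate compound 3 from compound 4. Nothing available here accounts for the size of this step.

Going by these compounds, whether the lower number is particular to chloro stays open, and bromo, trifluoromethyl or methoxy on the same carbon would test that. Also open, on these data alone, is whether the same exchange gives a step of similar size on the core of compound 1, with the group on another ring carbon.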